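A few compounds are considered here, and "the series" means these few. Any claim that something is new, unique, unknown or untested is made for them only; others in the source may bear on it.

Measured compounds:
compound 1 `CCCCN(CCCC)Cc1cn(CC(O)COC(=O)NCc2ccccc2)nn1` gives 42% in an assay on nucleic acid for inhibition of Nucleic Acid, read by fluorescence, tested at 100 uM; a lower number here means less inhibition, a higher number more inhibition at the concentration tested (going by the name of the read-out)
compound 2 `CCCCN(CCCC)Cc1cn(CC(O)COCc2ccccc2)nn1` gives 6%
compound 3 `CN(Cc1cn(CC(O)COCc2ccccc2)nn1)CC1CCCCC1` gives 6%

Compound 2 stands level with compound 3 at the digits shown, and the two together hold the lowest numbers of the three. Compound 1 sits well apart: a number 36 percentage points lower from compound 1 to compound 2 (beyond the scatter), a change at the oxygen on a saturated carbon. The other known step, no change at the digits printed from compound 2 to compound 3 (within the scatter), swaps the amine and changes nothing.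

Compound 4 `CCCCC(O)Cn1cc(CN(CCCC)CCCC)nn1` is compound 2 with its benzyloxy taken away: propyl in place of benzyloxy on a saturated chain carbon, two bonds along the chain from an oxygen on a saturated carbon. Neither known step touches this group. The large step from compound 1 to compound 2 concerns the benzylcarbamoyl, and the step from compound 2 to compound 3 concerns the amine, so the effect of losing the benzyloxy itself is not shown by any pair. Compound 2 already sits near the bottom of the scale, which leaves little room to fall further. The expectation is therefore no step beyond the scatter, a number 1 percentage points lower from compound 2 to compound 4 (within the scatter), with compound 4 estimated at 5%, within 0% to 18%.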

Compound 4, a percentage reported as inhibition, at one concentration (the size of the read-out at that concentration, not a potency): 18%
The estimate for compound 4 lay 13 percentage points below the measured number; the range from low to high includes it.
By their numbers in this assay, from the lowest: compounds 2 and 3 (each within the scatter of the next); then compound 4; then compound 1.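

Putting propyl in place of benzyloxy on a saturated chain carbon gives a number 12 percentage points higher from compound 2 to compound 4 (beyond the scatter) in this assay. For the compounds shown here, this is the first pair to test the benzyloxy itself, and it shows that the six-membered aromatic ring in that group is not required for the inhibition read at this concentration, since the number rises without it. Nothing available here explains the rise.

Two things changed together, the ring and the size of the group, and the compounds shown do not separate them: a benzyl-free ether such as cyclohexylmethoxy, or a longer chain such as hexyl, at this place would help to do so. Also open, from the compounds shown here alone, is whether the same swap gives a similar step when the dibutylamino is replaced by the (cyclohexylmethyl)(methyl)amino of compound 3.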